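Ethyl for hydrogen on the shared core: tolerability outlook

The source may hold more compounds than are shown below. What is called first, only, known or untested is meant among the compounds shown, and "the series" means these compounds.

Compound 1, `NC(=S)Nc1cccc(OCc2ccccc2)c1`: in an ADME assay on Ava5 cells (Homo sapiens) for cytotoxicity (a higher number here means that more compound is tolerated, a lower number that less compound is tolerated), compound 1 gives > 50000 nM, which is a limit of the assay.
Compound 2, `CNC(=S)Nc1cccc(OCCCCCc2ccccc2)c1`: in this assay compound 2 gives > 50000 nM, likewise a limit.

Compound 2 thus stands at the limit (the limit of > 50000 nM in this assay, at which 2 of the 2 values shown sit), and no number separates it from compound 1. Compound 3, `CCCNC(=S)Nc1cccc(OCCCCCc2ccccc2)c1`, differs from compound 2 by ethyl in place of hydrogen on a saturated chain carbon bound to an amide-type nitrogen. Among the compounds with values here, no measured pair shows the effect of such a change here. The expected step is a step that the limit leaves unreadable from compound 2 to compound 3, nothing beyond the usual scatter. Compound 3 is therefore estimated at 60000 nM, within 20000 nM to 200000 nM, most likely reported again only as a limit.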

Compound 3, half-maximal cytotoxic concentration: 32000 nM
Compound 3: middle estimate off by 1.9-fold (0.27 log units), on the high side; measured number inside the range.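

In this assay, within the data shown here, compound 3 gives 32000 nM, the first number on this series that is not a limit, so the methylamino to propylamino change brings the value into the readable range. The change gives an at least 1.5-fold lower number from compound 2 to compound 3 (0.19 log units; that floor lies within the scatter), and this floor alone does not establish a real drop in tolerance. Its full size cannot be read, and only one value here is an actual number: the limit of > 50000 nM in this assay, at which 2 of the 3 values shown sit.

On these data alone, whether a butyl or a longer chain in this place would lower the number further remains open. So does the effect of an amine at the end of that chain.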